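This account rests on a few compounds, and the source may have more. Where it says the series, first, only, none or still open, it means among the compounds named here.

Measured so far in an ADME assay on RAW264.7 cells (Mus musculus) for cytotoxicity, read by MTT assay, with a stated time of 48 h; on this read-out higher numbers stand for lower toxicity in this test and lower numbers for higher toxicity in this test:
- compound 1, `CC(=O)OC[C@H]1O[C@H](OC[C@@H](Cn2cc(CN(c3nc(-c4ccc(F)cc4)no3)C3CCCCC3)nn2)OC(C)=O)C=C[C@@H]1OC(C)=O`: 31.5 ug/mL
- compound 2, `CC(=O)OC[C@H]1O[C@H](OC[C@@H](Cn2cc(CN(c3nc(-c4ccc(C)cc4)no3)C3CCCCC3)nn2)OC(C)=O)C=C[C@@H]1OC(C)=O`: 45.3 ug/mL

Among the compounds with values here, compound 2 sits at one end of the two numbers; its only neighbour is compound 1, and the gap is the single measured step, a 1.4-fold higher number from compound 1 to compound 2 (0.16 log units; within the scatter), which does not exceed the scatter. Compound 3, `CC(=O)OC[C@H]1O[C@H](OC[C@@H](Cn2cc(CN(c3nc(-c4cccc(C)c4)no3)C3CCCCC3)nn2)OC(C)=O)C=C[C@@H]1OC(C)=O`, is not yet measured; it differs from compound 2 by 3-methylphenyl in place of 4-methylphenyl on an aromatic carbon. Within the data shown here, no measured step bears directly on this change, since the one step available concerns a different substituent exchange and is itself within the scatter. With nothing in the pair of measured compounds to suggest a shift, the expectation for compound 3 in this assay is a step of a 1.0-fold lower number from compound 2 to compound 3 (0.00 log units; within the scatter), that is, no change beyond the scatter. Compound 3 is therefore estimated at 45 ug/mL, with a likely range from 22 ug/mL to 90 ug/mL.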

Compound 3, half-maximal cytotoxic concentration: 46.4 ug/mL
Compound 3: middle estimate off by 1.0-fold (0.01 log units), on the low side, and the stated range covers the measured number.
By their numbers in this assay, from the lowest: compounds 1, 2 and 3 (each within the scatter of the next).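

In this assay the exchange shows a 1.0-fold higher number from compound 2 to compound 3 (0.01 log units; within the scatter), so moving the methyl from 4-methylphenyl to 3-methylphenyl on the aromatic carbon between the two ring nitrogen atoms separates nothing in this test. The exchange of 4-fluorophenyl for 3-methylphenyl reads the same way, with a 1.5-fold higher number from compound 1 to compound 3 (0.17 log units; within the scatter), so the three aryl groups shown cannot be told apart here, whether the substituent or its placing is exchanged. No measurement is at hand that explains why these numbers sit together.

Going by these compounds, whether this position responds at all to a group of a different kind, such as a carboxylic acid or an amine on the phenyl, stays open. Also open, on these data alone, is whether a methoxy or a chloro would read any differently from the fluoro and methyl, and whether any exchange here can exceed the scatter.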